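The source may hold more compounds than are shown below. What is called first, only, known or untested is meant among the compounds shown, and "the series" means these compounds.

Measured compounds in a functional assay on the whole organism for inhibition, with Mus musculus as the target, at a dose of 1 mg/kg by the oral route; on this read-out lower numbers stand for less inhibition and higher numbers for more inhibition at the one dose given (going by the name of the read-out):
- Compound 1, `COc1cccc2c1c(O)c(C(=O)N(C)c1c(F)cccc1F)c(=O)n2C`, gives 43%.
- Compound 2, `COc1cccc2c1c(O)c(C(=O)N(C)c1ccc(F)cc1F)c(=O)n2C`, gives 88%.
- Compound 3, `COc1cccc2c1c(O)c(C(=O)N(C)c1ccccc1Cl)c(=O)n2C`, gives 50%.

Compound 3 stands second highest of the three; its gap to compound 1 is within the scatter, while compound 2 sits well above it, a number 38 percentage points lower from compound 2 to compound 3 (beyond the scatter). Compound 4, `COc1cccc2c1c(O)c(C(=O)N(C)c1cccc(Cl)c1)c(=O)n2C`, has the same atoms as compound 3 joined differently: 3-chlorophenyl in place of 2-chlorophenyl on an amide-type nitrogen. Within the data shown here, no measured step moves a chlorine alone, so the closest guide is the step in which a fluorine changed place on the phenyl, a number 45 percentage points higher from compound 1 to compound 2 (beyond the scatter), and the step exchanging one halogen pattern for another, a number 38 percentage points lower from compound 2 to compound 3 (beyond the scatter). Both show that changing where a halogen sits on this phenyl can move this assay well beyond the scatter, but their directions give no clear rule for a chlorine. A modest rise is therefore expected for compound 4, a number 10 percentage points higher from compound 3 to compound 4 (within the scatter), with wide uncertainty. Compound 4 is estimated at 60%, expected between 30% and 85%.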

Compound 4, a percentage reported as inhibition, in the whole organism at one dose (the size of the read-out at that dose, not a potency): 85%
The estimate for compound 4 lay 25 percentage points below the measured number, within the range that was stated.
By their numbers in this assay, from the lowest: compounds 1 and 3 (each within the scatter of the next); then compounds 4 and 2 (each within the scatter of the next).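

Moving the single chlorine from 2-chlorophenyl to 3-chlorophenyl, with no atom gained or lost, changes the result in this assay strongly (a number 35 percentage points higher from compound 3 to compound 4 (beyond the scatter)). Until now, only a rearranged pair of fluorines had shown such a change, so the place of a halogen on this phenyl also matters for a single chlorine. The 2,4-difluorophenyl group is also no longer alone in giving a high number on this amide-type nitrogen: 3-chlorophenyl is level with it (a number 3 percentage points lower from compound 2 to compound 4 (within the scatter)) and well ahead of 2,6-difluorophenyl (a number 42 percentage points higher from compound 1 to compound 4 (beyond the scatter)).

From the compounds shown here alone, whether a nitrile, an amine or a carboxylic acid in place of the chlorine of 3-chlorophenyl would keep the number high stays open. Why this placement gives the higher number also stays open, as nothing at hand bears on it.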